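This account rests on a few compounds, and the source may have more. Where it says the series, first, only, none or still open, it means among the compounds named here.

Working notes on a small series built on one shared core. In a physicochemical assay for lipophilicity (a higher number here means a more lipophilic compound, a lower number a more polar compound), compound 1 (`COc1ccccc1C1=NC(c2ccccc2)CO1`) gives 3.76 and compound 2 (`Cc1ccc(C2=NC(c3ccccc3)CO2)cc1`) gives 4.11. Going by the values given here, compound 2 therefore holds the higher of the two numbers so far, and its gap to compound 1 lies beyond the scatter. Among the compounds with values here, these two compounds do not form a single-place step, so the series offers no measured step to borrow for the next change. Compound 3 (`Clc1ccc(C2=NC(c3ccccc3)CO2)cc1`) departs from compound 2 with chloro in place of methyl on an aromatic carbon, para to a large group (chloro in place of methyl on an aromatic carbon). In this assay, a small upward move that stays within the scatter is expected, estimated as a step of a number 0.14 log units higher from compound 2 to compound 3 (within the scatter). Compound 3 is expected to read 4.25, with an estimated range of 3.9 to 4.6.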

Compound 3, partition coefficient: 4.48
Estimate against measurement, compound 3: 0.23 log units below, within the range that was stated.
By their numbers in this assay, from the lowest: compound 1; then compound 2; then compound 3.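

In this assay, the series now has its first single-place step, a number 0.37 log units higher from compound 2 to compound 3 (beyond the scatter), which shows that chloro in place of methyl on an aromatic carbon, para to a large group, moves the number beyond the scatter. The two groups match in heavy-atom count, in hydrogen-bond donor and acceptor counts and in having no net charge, so this modest step arises with all of those counts unchanged. No accompanying measurement bears on the origin of the step.

This single step does not establish whether the same change would give a similar move at another aromatic carbon or on a different core. On these data alone, how an amine, a carboxylic acid or a longer chain would read at this position also remains open.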